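The compounds below may be only part of what the source reports. "The series", "measured", "known", "first", "only" and "open" are said of these compounds alone.

For the measured compounds named here, in a functional assay on SK-BR-3 cells (Homo sapiens) for cytotoxicity, read by MTT assay, with a stated time of 72 h (on this read-out lower numbers stand for stronger inhibition and higher numbers for weaker inhibition), compound 3 `N[C@H]1CC[C@H](Nc2c(C(=O)NCc3ccc(F)cc3)nc(Br)c3cccnc23)CC1` gives 2000 nM as the lowest of the two numbers so far. Compound 1 `N[C@H]1CC[C@H](Nc2c(C(=O)NCc3ccc(F)cc3)nc(N3CCCCS3(=O)=O)c3cccnc23)CC1` stands higher at 8500 nM and compound 2 `NCCCNc1c(C(=O)NCc2ccc(F)cc2)nc(Br)c2cccnc12` is recorded as "not determined" (no result reported) and so offers no comparison. The next structure is compound 4 `N[C@H]1CC[C@H](Nc2c(C(=O)NCc3ccc(F)cc3)nc(N3CCCCC3)c3cccnc23)CC1` and its change is piperidin-1-yl in place of bromo on an aromatic carbon with piperidin-1-yl in place of bromo on an aromatic carbon. Going by the values given here, the one measured step bearing on this is a 4.3-fold lower number from compound 1 to compound 3 (0.63 log units; beyond the scatter) where bromine replaced a six-membered non-aromatic ring. The new change runs the opposite way, so a rise of similar or smaller size is expected. In this assay the expected step is a 2.5-fold higher number from compound 3 to compound 4 (0.40 log units; beyond the scatter) by this estimate. The expected value for compound 4 is 5000 nM with an estimated range from 1800 nM to 14000 nM on this reasoning.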

Compound 4, half-maximal inhibitory concentration: > 10000 nM
Compound 4 gave a limit, no number (the forecaster's own chance of this, stated with the estimate: 10%); at least 2.0-fold (0.30 log units) between middle value and limit.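

In this assay compound 4 gives no number, only a limit of the assay: the limit of > 10000 nM in this assay, at which 1 of the 4 values shown sits. Piperidin-1-yl in place of bromo, on this carbon next to the ring nitrogen, brings a clear loss of activity, with an at least 5.0-fold higher number from compound 3 to compound 4 (0.69 log units; beyond the scatter) as the step. Neither ring-bearing compound can be placed ahead of the other, as an at least 1.1-fold higher number from compound 1 to compound 4 (0.07 log units; that floor lies within the scatter) gives only a floor.

So far bromo is the best group shown at this carbon. From the compounds shown here alone, whether a small open-chain amine such as dimethylamino, a nitrile or a morpholine ring would match it remains open.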